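Swapping Fluoropyridines on the Sulfonamide Nitrogen

A few compounds are considered here, and "the series" means these few. Any claim that something is new, unique, unknown or untested is made for them only; others in the source may bear on it.

Of the compounds shown here, three have been measured in a physicochemical assay for solubility; a higher number here means a more soluble compound, a lower number a less soluble compound. Compound 1 `Cc1nc(-c2cc(C(F)(F)F)ccc2[C@H]2CCOc3cc(S(=O)(=O)Nc4cccc(F)n4)ccc32)co1` gives 13000 nM, compound 2 `O=C1OCCN1c1cc(C(F)(F)F)ccc1[C@H]1CCOc2cc(S(=O)(=O)Nc3nccs3)ccc21` gives 295000 nM, and compound 3 `Cn1nccc1-c1cc(C(F)(F)F)ccc1[C@H]1CCOc2cc(S(=O)(=O)Nc3cccc(F)n3)ccc21` gives 27000 nM. Compound 3 thus stands second of the three, with compound 2 highest and compound 1 lowest.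

Compound 4 `Cn1nccc1-c1cc(C(F)(F)F)ccc1[C@H]1CCOc2cc(S(=O)(=O)Nc3ccc(F)cn3)ccc21` keeps everything else in compound 3 and changes one group on a sulfonamide nitrogen: 5-fluoropyridin-2-yl in place of 6-fluoropyridin-2-yl on a sulfonamide nitrogen. It has 5-fluoropyridin-2-yl in place of 6-fluoropyridin-2-yl, so the two have the same atoms, joined differently.

Among the compounds with values here, only one measured step involves a change in a single place: a 2.1-fold higher number from compound 1 to compound 3 (0.32 log units; beyond the scatter). That modest step puts 1-methyl-1H-pyrazol-5-yl in place of 2-methyl-1,3-oxazol-4-yl on an aromatic carbon, so it does not touch the sulfonamide nitrogen. Within the data shown here, no measured step speaks directly to the new change, and no clear direction can be drawn from the data. The expected step is therefore none beyond the scatter, estimated as a 1.1-fold lower number from compound 3 to compound 4 (0.03 log units; within the scatter). For compound 4 the estimated value is 25000 nM, with an expected range of 9000 nM to 70000 nM.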

Compound 4, solubility: 29000 nM
Compound 4: the middle estimate sits 1.2-fold (0.06 log units) below what was measured; measured number inside the range.
By their numbers in this assay, from the lowest: compound 1; then compounds 3 and 4 (each within the scatter of the next); then compound 2.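

With 5-fluoropyridin-2-yl in place of 6-fluoropyridin-2-yl on a sulfonamide nitrogen, this assay gives a 1.1-fold higher number from compound 3 to compound 4 (0.03 log units; within the scatter), so these two isomers cannot be told apart by their numbers. Within the data shown here, this is the first measured step at the sulfonamide nitrogen, since the earlier step, a 2.1-fold higher number from compound 1 to compound 3 (0.32 log units; beyond the scatter), lay on an aromatic carbon. Nothing measured here offers an explanation for this result.

This single pair leaves open whether the same exchange would also read within the scatter with the 2-methyl-1,3-oxazol-4-yl group of compound 1 in place of the 1-methyl-1H-pyrazol-5-yl group. It also leaves open how the number would respond to a group other than a fluoropyridine on the sulfonamide nitrogen, such as an unsubstituted pyridin-2-yl or a pyridine bearing a carboxylic acid.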